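Amide-nitrogen substituent variation in the dichlorophenyl lactam series

A few compounds are considered here, and "the series" means these few. Any claim that something is new, unique, unknown or untested is made for them only; others in the source may bear on it.

Compound 1 `NC1CCN(C2CN(CC[C@]3(c4ccc(Cl)c(Cl)c4)CCC(=O)N(CC4CC4)C3)C2)CC1` gives in an assay on isolated protein for inhibition of Substance-K receptor (Homo sapiens) (on this read-out higher numbers stand for weaker inhibition and lower numbers for stronger inhibition), a value of 6.31 nM. Compound 2 `CS(=O)(=O)N1CCN(C2CN(CC[C@]3(c4ccc(Cl)c(Cl)c4)CCC(=O)N(CC4CC4)C3)C2)CC1` gives in this assay a value of 7.94 nM, and the step of a 1.3-fold higher number from compound 1 to compound 2 (0.10 log units; within the scatter) lies within the scatter. Compound 2 therefore stands beside compound 1 on the two numbers shown, the pair being indistinguishable on this read-out.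

Compound 3 `CS(=O)(=O)N1CCN(C2CN(CC[C@]3(c4ccc(Cl)c(Cl)c4)CCC(=O)N(CC4CCC(F)(F)CC4)C3)C2)CC1` differs from compound 2 in one place: 4,4-difluorocyclohexyl in place of cyclopropyl on a saturated chain carbon bound to an amide-type nitrogen in a ring. Among the measured compounds shown here, no measured step touches the group on the amide-type ring nitrogen; the single recorded step, a 1.3-fold higher number from compound 1 to compound 2 (0.10 log units; within the scatter), changes a different part of the shared core and was itself within the scatter, so it offers no direction for the present change. Without a bearing step, no shift beyond the scatter is assumed, and the uncertainty is set wide.

For compound 3 the expected value in this assay is 8 nM, with a range from 2 nM to 32 nM. This corresponds to an expected step of a 1.0-fold higher number from compound 2 to compound 3 (0.00 log units; within the scatter), within the scatter.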

Compound 3, half-maximal inhibitory concentration: 1.26 nM
Beside the measured number, compound 3's estimate is 6.3-fold (0.80 log units) above it; measured number outside the range, below it.
By their numbers in this assay, from the lowest: compound 3; then compounds 1 and 2 (each within the scatter of the next).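

In this assay, the change from cyclopropyl to 4,4-difluorocyclohexyl gives a 6.3-fold lower number from compound 2 to compound 3 (0.80 log units; beyond the scatter), the first step shown to lie beyond the scatter, whereas the earlier change on a saturated ring carbon, a 1.3-fold higher number from compound 1 to compound 2 (0.10 log units; within the scatter), stayed within it. The number therefore responds to the group at this position, and cyclopropyl is not needed to keep it at the level of compound 1 and compound 2. No measurement shown accounts for the direction of this step.

A single replacement cannot separate the contribution of the six-membered ring from that of the two fluorine atoms, and a plain cyclohexyl group or a 4-fluorocyclohexyl group would bear on that question. Going by these compounds, whether 4,4-difluorocyclohexyl gives a similar step alongside the 4-aminopiperidin-1-yl group of compound 1 also remains open.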